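The source may report more compounds than this note shows. Statements on the series, on what has been measured and on what is new or still open speak of the compounds shown alone.

Measured so far:
compound 1, `CC(C)(C)OC(=O)N1CCN(CC(=O)Nc2ccc(C(=O)/C=C/c3cn(Cc4ccc(Br)cc4)nn3)cc2)CC1`, 25800 nM
compound 2, `CCCCCCCCn1cc(/C=C/C(=O)c2ccc(NC(=O)CN3CCN(c4ccccc4OC)CC3)cc2)nn1`, 21500 nM
compound 3, `CCCCCCCCCCn1cc(/C=C/C(=O)c2ccc(NC(=O)CN3CCN(c4ccccc4OC)CC3)cc2)nn1`, 87600 nM

All three were tested in a functional assay on SK-N-SH cells (Homo sapiens) for inhibition, read by MTT assay; on this read-out higher numbers stand for weaker inhibition and lower numbers for stronger inhibition. Compound 3 gives the highest number of the three: compound 1 stands nearest with a lower number, and compound 2 lies furthest below it. Going by the values given here, the only step measured between neighbouring structures is a 4.1-fold higher number from compound 2 to compound 3 (0.61 log units; beyond the scatter), a modest rise beyond the scatter that comes with a longer chain.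

Compound 4, `COc1ccccc1N1CCN(CC(=O)Nc2ccc(C(=O)/C=C/c3cn(Cc4ccc(Br)cc4)nn3)cc2)CC1`, has not yet been measured. It differs from compound 3 in one place: 4-bromophenyl in place of nonyl on a saturated chain carbon bound to an aromatic nitrogen. Among the compounds with values here, no measured step covers exactly this exchange, so the expectation rests on two observations. Compound 1, which carries the same 4-bromobenzyl group on a different core, gives 25800 nM in this assay. The shorter-chain relative of compound 3, compound 2, gives 21500 nM. Both numbers sit well below that of compound 3. For compound 4 the number is therefore expected to fall, roughly back to where compounds 1 and 2 stand, because compound 1 with the same 4-bromobenzyl group gives 25800 nM. The expected step is a 3.5-fold lower number from compound 3 to compound 4 (0.54 log units; beyond the scatter). The estimate for compound 4 is 25000 nM, with a range from 8000 nM to 80000 nM.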

Compound 4, half-maximal inhibitory concentration: 28000 nM
Estimate against measurement, compound 4: 1.1-fold (0.05 log units) below; the range from low to high includes it.
By their numbers in this assay, from the lowest: compounds 2, 1 and 4 (each within the scatter of the next); then compound 3.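

In this assay, the exchange of nonyl for 4-bromophenyl on the saturated chain carbon bound to an aromatic nitrogen (read one bond further out, decyl to 4-bromobenzyl) brings a 3.1-fold lower number from compound 3 to compound 4 (0.50 log units; beyond the scatter) and shows that this position accepts an aromatic ring as well as a chain. Two further comparisons show no real separation: 4-bromophenyl in place of heptyl at the same position gives a 1.3-fold higher number from compound 2 to compound 4 (0.11 log units; within the scatter) and 2-methoxyphenyl in place of tert-butoxycarbonyl on the amine nitrogen in a ring gives a 1.1-fold higher number from compound 1 to compound 4 (0.04 log units; within the scatter) and so, with 4-bromobenzyl in place, the exchange on that ring nitrogen has no effect that can be told from the scatter. Nothing available here accounts for why these numbers fall as they do.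

As far as these compounds go, it remains open whether the bromine contributes anything, which a plain benzyl or a 4-chlorobenzyl group at this position would address. From the compounds shown here alone, it is equally open how a much shorter chain such as butyl, or a free amine on the ring nitrogen, would read in this assay alongside these compounds.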